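Thiophene for Phenyl Carried onto a Second Nucleoside Core

A few compounds are considered here, and "the series" means these few. Any claim that something is new, unique, unknown or untested is made for them only; others in the source may bear on it.

Compound 1, `COc1ncnc2c1c(-c1ccsc1)cn2[C@@H]1O[C@H](CO)[C@@H](O)[C@H]1O`: in a functional assay on HepG2 cells (Homo sapiens) for antiproliferative activity, read by XTT assay, with a stated time of 72 h (on this read-out lower numbers stand for stronger inhibition and higher numbers for weaker inhibition), compound 1 gives 430 nM.
Compound 2, `COc1ncnc2c1c(-c1ccccc1)cn2[C@@H]1O[C@H](CO)[C@@H](O)[C@H]1O`: in this assay compound 2 gives > 20000 nM, which is a limit of the assay and not a number.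
Compound 3, `Nc1nc2c(c(-c3ccccc3)cn2[C@@H]2O[C@H](CO)[C@@H](O)[C@H]2O)c(=O)[nH]1`: in this assay compound 3 gives > 20000 nM, again a limit rather than a number.

Compounds 1 and 2 share a core and differ by one change, (thiophen-3-yl in place of phenyl on an aromatic carbon). That change made an at least 46-fold lower number from compound 2 to compound 1 (1.66 log units; beyond the scatter). Its true size is not fixed, because of the limit of > 20000 nM in this assay, at which 2 of the 3 values shown sit; the gap can only be given as a floor.

Compound 3 carries a different core; the difference between the two cores is not broken down here. Compound 4, `Nc1nc2c(c(-c3ccsc3)cn2[C@@H]2O[C@H](CO)[C@@H](O)[C@H]2O)c(=O)[nH]1`, is compound 3 with the same change, (thiophen-3-yl in place of phenyl on an aromatic carbon).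

Compound 4 is expected to move by an at least 10-fold lower number from compound 3 to compound 4 (1.00 log units; beyond the scatter), a step also read only as a floor, since compound 3 sits at a limit. The expectation rests on compound 2 giving > 20000 nM while compound 1 gives 430 nM, with no guarantee that the second core answers alike. Compound 4 is therefore estimated at 2000 nM, within 400 nM to 20000 nM.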

Compound 4, half-maximal inhibitory concentration: > 20000 nM
Compound 4: a limit, no number; the forecaster's own chance of this, stated with the estimate: 30%; middle value at least 10-fold (1.00 log units) away from the limit.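

Compound 3 and compound 4 both end at a limit of the assay and not at a number, so the swap of phenyl for thiophen-3-yl on this core gives no readable step: the limit of > 20000 nM in this assay, at which 3 of the 4 values shown sit.

The compounds shown leave open whether thiophen-3-yl changes anything at all on the core of compound 3.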